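From Compound 1 to Compound 4: An Aromatic Ring Swap

The compounds below may be only part of what the source reports. "The series", "measured", "known", "first", "only" and "open" are said of these compounds alone.

Compound 1 `O=C(O)c1csc([C@H]2CC[C@@H]3[C@@H](COc4cccc(F)c4)[C@H](O)C[C@@H]3O2)n1` is the reference point of this step. In a functional assay on CHO cells for agonist activity at prostaglandin E2 receptor EP2 subtype (Homo sapiens), read by HTRF and cAMP accumulation, with a stated time of 30 min (on this read-out higher numbers stand for an effect only at larger amounts of compound and lower numbers for an effect already at smaller amounts), compound 1 gives 5.4 nM, which places it second highest among the three measured compounds. Compound 2 `O=C(O)c1csc([C@H]2CC[C@@H]3[C@@H](CCCCCOc4ccccc4)[C@H](O)C[C@@H]3O2)n1` gives 28 nM in this assay, a higher number than compound 1. Among the measured compounds shown here, compound 3 `O=C(O)c1csc([C@H]2CC[C@@H]3[C@@H](COc4cccc(OC(F)(F)F)c4)[C@H](O)C[C@@H]3O2)n1` gives 0.9 nM, the lowest number of the three, and the step of a 6.0-fold lower number from compound 1 to compound 3 (0.78 log units; beyond the scatter) is the only measured change that bears on the present case.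

Compound 4 `O=C(O)c1csc([C@H]2CC[C@@H]3[C@@H](COc4ccccc4C(F)(F)F)[C@H](O)C[C@@H]3O2)n1` has not yet been measured. It differs from compound 1 in one place: 2-(trifluoromethyl)phenyl in place of 3-fluorophenyl on an oxygen on a saturated carbon. The measured step shows that replacing the fluoro group with trifluoromethoxy on the aromatic ring lowers the number beyond the scatter. The entering 2-(trifluoromethyl)phenyl of compound 4 also carries three fluorines, but it is not the trifluoromethoxy-bearing ring of compound 3, so that step is only a partial guide. A lowering relative to compound 1 is expected, though one that may stay within the scatter. Compound 4 is therefore estimated to give about 3 nM, with a range from 0.7 nM to 15 nM. The expected step of a 1.8-fold lower number from compound 1 to compound 4 (0.26 log units; within the scatter) is estimated to be modest at most.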

Compound 4, half-maximal effective concentration: 0.5 nM
Estimate against measurement, compound 4: 6.0-fold (0.78 log units) above; the measured number lies below the stated range.
By their numbers in this assay, from the lowest: compounds 4 and 3 (each within the scatter of the next); then compound 1; then compound 2.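

The step of an 11-fold lower number from compound 1 to compound 4 (1.03 log units; beyond the scatter) shows that the lowering at this place, on an oxygen on a saturated carbon, is not tied to the trifluoromethoxy ring of compound 3: a 2-(trifluoromethyl)phenyl in place of 3-fluorophenyl also gives a large step, beyond the scatter. In this assay compound 3 gives 0.9 nM and compound 4 gives 0.5 nM, two values within the scatter of each other, so two differently substituted rings both reach this level, and the data do not set one ahead of the other. Nothing in the available evidence accounts for the step.

Because the substituent and its place on the ring change together in this swap, the compounds shown leave open how much of the step belongs to the trifluoromethyl group itself and how much to the loss of the 3-fluorophenyl ring. From the compounds shown here alone, a plain phenyl, or a ring carrying a chloro or a nitrile group, at this same place would be needed to separate the two, and how far the result holds for such rings remains unknown.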